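This account rests on a few compounds, and the source may have more. Where it says the series, first, only, none or still open, it means among the compounds named here.

Measured compounds:
- Compound 1 `COCC(=O)Nc1ccc2c(cnn2CC(=O)COc2ccc(Oc3ccccc3)cc2)c1` gives 6300 nM in an assay on microsomes from brain for inhibition of Fatty-acid amide hydrolase 1 (Rattus norvegicus), read by fluorescence and HPLC, with a stated time of 45 min; a higher number here means a weaker inhibitor, a lower number a stronger inhibitor.
- Compound 2 `O=C(COc1ccc(Oc2ccccc2)cc1)Cn1ncc2cc(NC(=O)CO)ccc21` gives 5400 nM in this assay.
- Compound 3 `O=C(COc1ccc(Oc2ccccc2)cc1)Cn1ncc2cc(NC(=O)Nc3ccccc3)ccc21` gives 6000 nM in this assay.

All three numbers lie close together. Compound 3 stands second highest of the three, but its distance to compound 1 and to compound 2 is within the usual scatter, so no order among them can be read from these numbers.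

Compound 4 `CS(=O)(=O)NC(=O)c1ccc2c(cnn2CC(=O)COc2ccc(Oc3ccccc3)cc2)c1` has not yet been measured. It differs from compound 3 in one place: (methylsulfonyl)carbamoyl in place of (phenylcarbamoyl)amino on an aromatic carbon. The measured steps that touch this position are a 1.1-fold lower number from compound 1 to compound 3 (0.02 log units; within the scatter) and a 1.1-fold higher number from compound 2 to compound 3 (0.05 log units; within the scatter); the remaining step, a 1.2-fold lower number from compound 1 to compound 2 (0.07 log units; within the scatter), sits at the same place. None of these steps moved the number beyond the scatter, and none of them puts a (methylsulfonyl)carbamoyl group there, so the change in compound 4 is new in kind. For the measured compounds named here, with no measured step pointing in either direction, the expectation for compound 4 is a step of about no change at the digits printed from compound 3 to compound 4 (within the scatter), that is, no change beyond the scatter. Compound 4 is therefore estimated at 6000 nM, with a range from 2000 nM to 20000 nM.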

Compound 4, half-maximal inhibitory concentration: 770 nM
Beside the measured number, compound 4's estimate is 7.8-fold (0.89 log units) above it, outside the stated range (below it).
By their numbers in this assay, from the lowest: compound 4; then compounds 2, 3 and 1 (each within the scatter of the next).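

In this assay, this aromatic carbon proves sensitive to what it carries: the number falls with a 7.8-fold lower number from compound 3 to compound 4 (0.89 log units; beyond the scatter) and with a 7.0-fold lower number from compound 2 to compound 4 (0.85 log units; beyond the scatter) and again with an 8.2-fold lower number from compound 1 to compound 4 (0.91 log units; beyond the scatter) in the same direction, although the three earlier groups stay within the scatter of each other. The earlier groups are all joined to the aromatic carbon through an amino nitrogen, whereas (methylsulfonyl)carbamoyl is joined through its carbonyl carbon and brings a sulfur atom and a methylsulfonyl end. No measurement here explains why this change lowers the number.

These compounds leave open whether the reversed link or the methylsulfonyl end accounts for the step, since the two arrive together. A plain carbamoyl or a carboxylic acid on this aromatic carbon would help separate them.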